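Bromo to trifluoromethyl on the fused core

The source may report more compounds than this note shows. Statements on the series, on what has been measured and on what is new or still open speak of the compounds shown alone.

Of the compounds shown here, two have been measured in an assay for inhibition of Tryptophan 2,3-dioxygenase (Homo sapiens), with stated times of 10 min and 60 min; a higher number here means a weaker inhibitor, a lower number a stronger inhibitor. Compound 2 `O=[N+]([O-])c1ccc(CNc2cc(Br)cc3[nH]ncc23)cc1` gives 2230 nM in this assay. Compound 1 `Oc1ccc(CNc2cc(C(F)(F)F)cc3[nH]ncc23)cc1` gives 2550 nM in this assay, and the two values lie within the usual scatter of each other, so neither stands apart. Compound 3 `O=[N+]([O-])c1ccc(CNc2cc(C(F)(F)F)cc3[nH]ncc23)cc1` differs from compound 2 by a single change: trifluoromethyl in place of bromo on an aromatic carbon. Among the measured compounds shown here, no measured pair shows this change on its own, so no step can be read from the data. Compound 3 is expected to give 2400 nM in this assay, with a range from 1000 nM to 5500 nM. The step from compound 2 to compound 3 is thus estimated at a 1.1-fold higher number from compound 2 to compound 3 (0.03 log units; within the scatter), which is no change beyond the scatter.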

Compound 3, half-maximal inhibitory concentration: > 100000 nM
Compound 3 was reported as a limit; the forecaster's own chance of this, stated with the estimate: 5%; at least 41-fold (1.61 log units) between middle value and limit.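

With nitro kept on the benzyl-side ring, trifluoromethyl in place of bromo on this aromatic carbon gives an at least 44-fold higher number from compound 2 to compound 3 (1.65 log units; beyond the scatter). With trifluoromethyl kept, nitro in place of hydroxy gives an at least 39-fold higher number from compound 1 to compound 3 (1.59 log units; beyond the scatter), so each group appears in a compound with a measured number, and only compound 3, which carries both, falls away. Compound 3 is reported as a limit in this assay: the limit of > 100000 nM in this assay, at which 1 of the 3 values shown sits.

The compounds shown leave open what pairing hydroxy with bromo would give. They also leave open how a methyl group, chlorine or an amine would behave on this carbon alongside nitro.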